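Extending the Phenylalkyl Chain from Compound 3 to Compound 4

The source may report more compounds than this note shows. Statements on the series, on what has been measured and on what is new or still open speak of the compounds shown alone.

Compound 1 `C[C@@H](CC(=O)O)CC(=O)c1c([C@@H](O)CCCCCc2ccccc2)n(C)c2ccc(Cl)cc12` — 120 nM
Compound 2 `CC(CC(=O)O)CC(=O)c1c(CCCCCCc2ccccc2)n(C)c2ccc(Cl)cc12` — 0.28 nM
Compound 3 `CC(CC(=O)O)CC(=O)n1c(CCCc2ccccc2)cc2ccc(Cl)cc21` — 210 nM

All three were measured in a functional assay for antagonist activity at Oxoeicosanoid receptor 1 (Homo sapiens), read by fluorescence and calcium flux, with stated times of 2 min and 1 min; a lower number here means a stronger inhibitor, a higher number a weaker inhibitor. Compound 3 gives the highest number of the three; its value and that of compound 1 lie within the usual scatter of each other, while compound 2 sits far below both, beyond the scatter. Compound 4 `CC(CC(=O)O)CC(=O)n1c(CCCCCc2ccccc2)cc2ccc(Cl)cc21` is compound 3 with one change: phenethyl in place of phenyl on a saturated chain carbon, three bonds along the chain from an aromatic carbon. For the measured compounds named here, no measured pair shows this chain extension alone. Still, the far lower number of compound 2, 0.28 nM, which carries a longer phenylalkyl chain on a different core, hints that a longer chain may go with a stronger inhibitor. The step from compound 3 to compound 4 is expected to be a lowering, a 7.0-fold lower number from compound 3 to compound 4 (0.85 log units; beyond the scatter), beyond the scatter. Compound 4 is estimated at 30 nM, with a range from 5 nM to 150 nM.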

Compound 4, half-maximal inhibitory concentration: 2.1 nM
Beside the measured number, compound 4's estimate is 14-fold (1.15 log units) above it; the measured number lies below the stated range.
By their numbers in this assay, from the lowest: compound 2; then compound 4; then compounds 1 and 3 (each within the scatter of the next).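

In this assay, the chain on this core proves highly sensitive to its length: phenethyl in place of phenyl on a saturated chain carbon, three bonds along the chain from an aromatic carbon, gives a 100-fold lower number from compound 3 to compound 4 (2.00 log units; beyond the scatter) as a large step. This is the first pair shown that isolates a chain extension, so the effect no longer rests on a comparison across different cores. Nothing available here explains the size of this step.

Going by these compounds, whether a longer chain on this core would lower the number further or raise it remains open. So does the effect of an amine or an ether oxygen placed within the chain.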